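Alkyne-linked phenoxyacetic acids: sulfonamide to sulfone step

This account rests on a few compounds, and the source may have more. Where it says the series, first, only, none or still open, it means among the compounds named here.

Measured compounds in an assay on CHO cells for displacement of a labelled ligand from prostaglandin D2 receptor 2 (Homo sapiens), read by scintillation counting; on this read-out higher numbers stand for weaker inhibition and lower numbers for stronger inhibition:
- compound 1, `Cc1ccc(S(=O)(=O)N(C)CC(C)C)cc1C#Cc1cc(Cl)ccc1OCC(=O)O`, 4.2 nM
- compound 2, `CCCS(=O)(=O)c1ccc(F)c(C#Cc2cc(Cl)ccc2OCC(=O)O)c1`, 3.4 nM
- compound 3, `CN(c1cccc(C#Cc2cc(Cl)ccc2OCC(=O)O)c1)S(C)(=O)=O`, 122 nM

Compound 1 gives the second highest of the three numbers. Compound 2 sits within the scatter of compound 1, so the two cannot be ordered. Compound 3 lies far beyond the scatter, with a much higher number than compound 1.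

Compound 4, `Cc1ccc(S(=O)(=O)CC(C)C)cc1C#Cc1cc(Cl)ccc1OCC(=O)O`, is not yet measured. It differs from compound 1 in one place: isobutyl in place of isobutyl(methyl)amino on a sulfonyl sulfur. Among the compounds with values here, no measured pair in the set shows this change, so its effect is not known from the data. Compound 2, which carries no nitrogen on its sulfonyl sulfur, gives 3.4 nM, within the scatter of compound 1; this offers no sign that removing the nitrogen costs potency.

The step of a 1.2-fold higher number from compound 1 to compound 4 (0.08 log units; within the scatter) is expected to stay within the scatter, in no firm direction. Compound 4 is estimated at 5 nM, with a range from 1.5 nM to 15 nM.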

Compound 4, inhibition constant: 3 nM
Beside the measured number, compound 4's estimate is 1.7-fold (0.22 log units) above it; the range from low to high includes it.
By their numbers in this assay, from the lowest: compounds 4, 2 and 1 (each within the scatter of the next); then compound 3.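

Within the data shown here, compound 1 and compound 4 form the first pair that isolates this change, and this assay gives a 1.4-fold lower number from compound 1 to compound 4 (0.15 log units; within the scatter) for this exchange on a sulfonyl sulfur whose other neighbour is an aromatic carbon. Within this pair, the sulfonyl group can therefore carry isobutyl in place of isobutyl(methyl)amino, losing the nitrogen and its methyl, with no step beyond the scatter. No measured evidence here bears on the result, so the reason for this small step remains unknown.

From the compounds shown here alone, it remains open whether a longer chain, a cyclopropyl ring or a phenyl ring on the same sulfur would keep the value within the scatter of compound 4. A terminal amine or carboxylic acid on the isobutyl chain is equally unresolved.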